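Adding one hydroxy group to compound 2

This account rests on a few compounds, and the source may have more. Where it says the series, first, only, none or still open, it means among the compounds named here.

Compound 1 (`COc1ccc2cc(-c3ccccc3)c(O)nc2c1`) gives 10000 nM
Compound 2 (`COc1cc(OC)c2cc(-c3ccccc3)c(O)nc2c1`) gives 10000 nM
Compound 3 (`Cn1c(=O)c(-c2ccc(O)cc2)cc2c(O)cc(O)cc21`) gives 10000 nM

In a functional assay on U-373MG ATCC cells for cytotoxicity against U373 MG (Homo sapiens), read by colorimetric assay and MTT assay (a lower number here means a stronger inhibitor, a higher number a weaker inhibitor), compound 2 stands level with compounds 1 and 3. Compound 4 (`COc1cc(OC)c2cc(-c3ccc(O)cc3)c(O)nc2c1`) differs from it in one place: hydroxy in place of hydrogen on an aromatic carbon, which turns phenyl into 4-hydroxyphenyl. Within the data shown here, the only measured step, no change at the digits printed from compound 1 to compound 2 (within the scatter), is a different change, methoxy in place of hydrogen, so it offers only indirect guidance. Compound 3, which already carries 4-hydroxyphenyl on a different core, gives 10000 nM as well. No step beyond the scatter is therefore expected, and the estimated step is no change at the digits printed from compound 2 to compound 4 (within the scatter) in size. Compound 4 is estimated at 10000 nM (5000 nM to 20000 nM).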

Compound 4, half-maximal inhibitory concentration: 10000 nM
Compound 4: the middle estimate sits on the measured number at the digits printed; measured number inside the range.
By their numbers in this assay, from the lowest: compounds 1, 2, 3 and 4 (each within the scatter of the next).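

In this assay, among these compounds, hydroxy in place of hydrogen on the phenyl ring, para to a large group, gives no change at the digits printed from compound 2 to compound 4 (within the scatter) for the first direct reading of this position. The earlier step covered only a methoxy change on the core, whereas this one shows that turning phenyl into 4-hydroxyphenyl on the shared core leaves the printed number unchanged. No available evidence explains this result. Still open, from the compounds shown here alone, is whether an amine, a carboxylic acid or a longer chain at this same place would shift the number.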